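Aryl variation on the sulfonamide core: working notes

A few compounds are considered here, and "the series" means these few. Any claim that something is new, unique, unknown or untested is made for them only; others in the source may bear on it.

Measured compounds:
compound 1 `Cc1ccc(S(=O)(=O)Nc2ccc(-c3ccccc3)c3cccnc23)cc1` gives 7220 nM in a functional assay on A549 cells (Homo sapiens) for antiproliferative activity, with a stated time of 2 days; on this read-out lower numbers stand for stronger inhibition and higher numbers for weaker inhibition
compound 2 `Cc1ccc(S(=O)(=O)Nc2ccc(-c3ccsc3)c3cccnc23)cc1` gives 4630 nM in this assay

For the measured compounds named here, compound 2 stands at the lower of the two numbers so far, but the only step that leads to it, a 1.6-fold lower number from compound 1 to compound 2 (0.19 log units; within the scatter), lies within the scatter, so compound 2 and compound 1 cannot be placed in any order on this read-out.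

Compound 3 `Cc1ccc(S(=O)(=O)Nc2ccc(-c3cc4ccccc4s3)c3cccnc23)cc1` is not yet measured. It differs from compound 2 by 1-benzothiophen-2-yl in place of thiophen-3-yl on an aromatic carbon; the new group sits on an aromatic carbon of a six-membered aromatic ring of carbon only, part of a fused or bridged system of two rings.

Going by the values given here, only one measured step bears on this change, and it concerns the same position: exchanging phenyl for thiophen-3-yl gave a 1.6-fold lower number from compound 1 to compound 2 (0.19 log units; within the scatter), a step inside the scatter. Among the compounds with values here, the present change again swaps the aryl group at that position, now for a larger fused ring, so no firm direction can be read from the one step available. A small shift in this assay, if any, is the expectation, with the uncertainty widened by the size of the new group.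

The estimate for compound 3 in this assay is 3200 nM, within 1000 nM to 10000 nM, which would mean an expected step of a 1.4-fold lower number from compound 2 to compound 3 (0.16 log units; within the scatter).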

Compound 3, half-maximal inhibitory concentration: "not active" (no number reported)
The entry for compound 3 holds no number, and the estimate cannot be compared.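

For the compounds shown here, compound 3 is entered as "not active" in this assay with no number reported, so no step from compound 2 to compound 3 can be read. Nothing available bears on this result. The compounds shown leave open how 1-benzothiophen-2-yl at this place compares numerically with thiophen-3-yl or phenyl.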